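This account rests on a few compounds, and the source may have more. Where it says the series, first, only, none or still open, it means among the compounds named here.

Measured compounds:
- compound 1, `CC1CN(C(=O)c2ccc(-c3ccc(NC(=O)Nc4ccc(Cl)c(C(F)(F)F)c4)cc3)cc2)CC(C)O1`: > 50000 nM in a functional assay on MX1 cells (Homo sapiens) for inhibition, read by MTT assay, with a stated time of 120 h; a lower number here means a stronger inhibitor, a higher number a weaker inhibitor
- compound 2, `CC(NC(=O)/C=C/c1ccc(NC(=O)Nc2ccc(Cl)c(C(F)(F)F)c2)cc1)c1ccccc1`: 3130 nM in this assay
- compound 3, `C/C(=C\C(=O)N1CC(C)OC(C)C1)c1ccc(NC(=O)Nc2ccc(Cl)c(C(F)(F)F)c2)cc1`: > 50000 nM in this assay

The value for compound 3 is a limit, not a number. The same holds for compound 1, whose value is also a limit. Compound 2 is the only one of the three that yields a number in this assay. Compound 3 therefore stands at the limit of > 50000 nM in this assay, at which 2 of the 3 values shown sit, and it is this end of the shown range that any change must move it away from.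

Compound 4, `C/C(=C\C(=O)NC(C)c1ccccc1)c1ccc(NC(=O)Nc2ccc(Cl)c(C(F)(F)F)c2)cc1`, differs from compound 3 in one place: (1-phenylethyl)amino in place of 2,6-dimethylmorpholin-4-yl on a carbonyl carbon. Compound 2 carries this same (1-phenylethyl)amino group on its carbonyl carbon, and compound 2 gives 3130 nM. Compound 3, with the 2,6-dimethylmorpholin-4-yl group, stays at its limit. Among the compounds with values here, no step between measured compounds is available to size the change directly, but the contrast between compound 2 and the two morpholine amides suggests a gain beyond the scatter. For compound 4 the estimated step from its parent is an at least 8.3-fold lower number from compound 3 to compound 4 (0.92 log units; beyond the scatter), in the direction of stronger inhibition. Compound 4 is thus expected to reach 6000 nM, within a range of 1500 nM to 30000 nM, with some chance that it still returns only a limit.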

Compound 4, half-maximal inhibitory concentration: > 50000 nM
Compound 4: no number, only a limit; the forecaster's own chance of this, stated with the estimate: 30%; at least 8.3-fold (0.92 log units) between middle value and limit.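

In this assay compound 4 gives > 50000 nM, which is a limit and not a number. Compound 3 also returned only a limit, so no step can be read from compound 3 to compound 4. The compounds shown leave open whether (1-phenylethyl)amino in place of 2,6-dimethylmorpholin-4-yl on a carbonyl carbon changes inhibition at all, and compound 4 stands at the same end of the range as compound 3: the limit of > 50000 nM in this assay, at which 3 of the 4 values shown sit.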